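Swapping a cyclohexenyl ring for a butyl chain

The source may hold more compounds than are shown below. What is called first, only, known or untested is meant among the compounds shown, and "the series" means these compounds.

Measured so far:
Compound 1, `COc1ccc(-c2cn(Cc3ccccc3)nn2)cc1`, gives 146000 nM in a functional assay on HT-1080 cells (Homo sapiens) for antiproliferative activity, read by MTT assay, with a stated time of 72 h; a higher number here means a weaker inhibitor, a lower number a stronger inhibitor.
Compound 2, `C1=C(c2cn(Cc3ccccc3)nn2)CCCC1`, gives 219000 nM in this assay.

Both compounds share a core and differ only in the group attached to it. Compound 2 and compound 1 are close to each other: the gap between their values lies within the usual scatter of repeated measurements, so neither can be called the stronger or weaker of the two. Both are weak inhibitors on these cells.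

Compound 3, `CCCCc1cn(Cc2ccccc2)nn1`, has not yet been measured. It differs from compound 2 in one place: butyl in place of cyclohex-1-en-1-yl on an aromatic carbon. Among the compounds with values here, no measured pair shows what a change of this kind does here, so there is nothing to build on except the two weak values already seen. The expectation is therefore a step of no more than the scatter, in either direction, a 1.1-fold higher number from compound 2 to compound 3 (0.06 log units; within the scatter). Compound 3 is estimated at 250000 nM in this assay, with a plausible range from 100000 nM to 600000 nM.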

Compound 3, half-maximal inhibitory concentration: > 100000 nM
Compound 3: only a limit was reported (the forecaster's own chance of this, stated with the estimate: 25%); the middle value lies beyond the limit too.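

In this assay compound 3 gives > 100000 nM, which is a limit and not a number, so the step from compound 2 to compound 3 cannot be read. From the compounds shown here alone, whether butyl in place of cyclohex-1-en-1-yl changes the activity at all, and in which direction, stays open.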